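A Second Methyl on the Aryl Ring of a Chromenone

The compounds below may be only part of what the source reports. "The series", "measured", "known", "first", "only" and "open" are said of these compounds alone.

Measured so far in a functional assay on KB cells (Homo sapiens) for antiproliferative activity, read by sulforhodamine B assay, with a stated time of 3 days; a lower number here means that less compound is needed, a higher number that more compound is needed for the effect:
Compound 1 `CCCCc1ccc(-c2cc(=O)c3c(o2)C(CC)(CC)C(=O)C(CC)=C3O)cc1` gives 111 uM.
Compound 2 `CCC1=C(O)c2c(oc(-c3ccc(OC(F)(F)F)cc3)cc2=O)C(CC)(CC)C1=O` gives 36.5 uM.
Compound 3 `CCC1=C(O)c2c(oc(-c3cccc(C)c3)cc2=O)C(CC)(CC)C1=O` gives 49.7 uM.

Compound 3 stands second highest of the three numbers, with compound 2 within the scatter of it and compound 1 the furthest away. Compound 4 `CCC1=C(O)c2c(oc(-c3cc(C)cc(C)c3)cc2=O)C(CC)(CC)C1=O` differs from compound 3 by methyl in place of hydrogen on an aromatic carbon, reading 3-methylphenyl to 3,5-dimethylphenyl one bond further out. Going by the values given here, the only measured step, a 3.0-fold lower number from compound 1 to compound 2 (0.48 log units; beyond the scatter), concerns a different substituent and does not bear on adding a second methyl; no measured pair shows this change. The expectation is therefore a step of a 1.1-fold lower number from compound 3 to compound 4 (0.04 log units; within the scatter), none beyond the scatter, in this assay. Compound 4 is estimated at 45 uM, within 20 uM to 110 uM.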

Compound 4, concentration for half-maximal effect: 45.5 uM
Estimate against measurement, compound 4: 1.0-fold (0.00 log units) below; the measured number falls inside the stated range.
By their numbers in this assay, from the lowest: compounds 2, 4 and 3 (each within the scatter of the next); then compound 1.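

In this assay, going by these compounds alone, methyl in place of hydrogen on this aromatic carbon, meta to a large group and meta to a methyl group, gives a 1.1-fold lower number from compound 3 to compound 4 (0.04 log units; within the scatter) and is the first measured step at this position. At this level of the assay, 3-methylphenyl and 3,5-dimethylphenyl therefore cannot be told apart. No measured evidence here accounts for this result. The compounds shown leave open whether an amine or a carboxylic acid on this carbon would give a step beyond the scatter.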